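The source may hold more compounds than are shown below. What is called first, only, known or untested is meant among the compounds shown, and "the series" means these compounds.

Measured so far:
compound 1 `Fc1ccc(NC(=S)Nc2cccc(C(F)(F)F)c2)cc1Cl`: 8000 nM
compound 2 `COc1cccc(NC(=S)Nc2cccc(C(F)(F)F)c2)c1`: 26000 nM

In an ADME assay on MT4 cells (Homo sapiens) for cytotoxicity (a higher number here means that more compound is tolerated, a lower number that less compound is tolerated), compound 2 gives 26000 nM, the highest of the two numbers at hand. Its nearest neighbour is compound 1, which in this assay gives 8000 nM, a lower number beyond the scatter. For the measured compounds named here, the two differ in more than one place, so no single-point step between measured compounds is available.

Compound 3 `Fc1cccc(NC(=S)Nc2cccc(C(F)(F)F)c2)c1` is not yet measured. It differs from compound 2 in one place: fluoro in place of methoxy on an aromatic carbon. The change sits on an aromatic carbon of a six-membered aromatic ring of carbon only, meta to a large group. The expected step of a 1.7-fold lower number from compound 2 to compound 3 (0.24 log units; within the scatter) is towards a lower number, of modest size, because compound 1 also carries fluoro on that ring and gives 8000 nM. Compound 3 is therefore expected at 15000 nM, with a range from 6000 nM to 40000 nM.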

Compound 3, half-maximal cytotoxic concentration: 20000 nM
Compound 3: middle estimate off by 1.3-fold (0.12 log units), on the low side; low and high end bracket the measured number.
By their numbers in this assay, from the lowest: compound 1; then compounds 3 and 2 (each within the scatter of the next).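

In this assay, for the compounds shown here, the exchange of methoxy for fluoro on this aromatic carbon gives a 1.3-fold lower number from compound 2 to compound 3 (0.11 log units; within the scatter) and so, as the first comparison that differs in one place, does not separate the two compounds. At this position, on an aromatic carbon meta to a large group, losing the hydrogen-bond acceptor counted for methoxy brings no step beyond the scatter. No measured evidence bears on why the two groups read alike here.

On these data alone, whether a different kind of group at this same carbon, such as an amine or a carboxylic acid, would give a step beyond the scatter remains open. Also open, as far as these compounds go, is whether a longer chain such as ethoxy reads like methoxy, and whether the exchange of methoxy for fluoro reads the same elsewhere on this ring.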